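Swapping the Amide Aryl Group: Pyridine to Furan

The source may report more compounds than this note shows. Statements on the series, on what has been measured and on what is new or still open speak of the compounds shown alone.

compound 1, `Cc1ccc(N2CCN(CCNC(=O)c3ccco3)CC2)cc1`: 339 nM
compound 2, `Cc1ccc(N2CCN(CCNC(=O)c3cccnc3)CC2)c(C)c1`: 1150 nM

In a functional assay for antagonist activity at Adrenergic receptor alpha-1 (Rattus norvegicus) (a higher number here means weaker binding, a lower number tighter binding), compound 2 stands highest of the two numbers; compound 1 is the nearest, with the lower value. Compound 3, `Cc1ccc(N2CCN(CCNC(=O)c3ccco3)CC2)c(C)c1`, has not been measured. It differs from compound 2 by furan-2-yl in place of pyridin-3-yl on a carbonyl carbon. For the measured compounds named here, no measured pair isolates this change, so its size is unknown. Compound 1 carries the entering furan-2-yl group and gives 339 nM in this assay. Compound 3 is expected to give 550 nM, within a range from 200 nM to 1500 nM. The expected step of a 2.1-fold lower number from compound 2 to compound 3 (0.32 log units; beyond the scatter) is a modest move toward a lower number, possibly no larger than the scatter.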

Compound 3, dissociation constant: 19.1 nM
For compound 3 the middle estimate is 29-fold (1.46 log units) above the measured one; the whole stated range lies above it.
By their numbers in this assay, from the lowest: compound 3; then compound 1; then compound 2.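

In this assay the change from pyridin-3-yl to furan-2-yl on a carbonyl carbon gives a 60-fold lower number from compound 2 to compound 3 (1.78 log units; beyond the scatter) and so shows that this position responds strongly to the aryl group. Methyl in place of hydrogen on an aromatic carbon gives an 18-fold lower number from compound 1 to compound 3 (1.25 log units; beyond the scatter) as well, so a second place in these compounds also carries a large step. Nothing at hand accounts for either step. The compounds shown leave open whether the furan-2-yl step keeps its size without that methyl, and whether the methyl step holds with pyridin-3-yl on the carbonyl carbon. They also leave open how thiophen-2-yl or phenyl would compare there.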